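From Dimethylamino to Amino: What Compound 4 Might Show

The source may report more compounds than this note shows. Statements on the series, on what has been measured and on what is new or still open speak of the compounds shown alone.

Of the compounds shown here, three have so far been measured in a functional assay on EL4 cells (Mus musculus) for inhibition, tested at 100 uM; on this read-out lower numbers stand for less inhibition and higher numbers for more inhibition at the one concentration tested (going by the name of the read-out). Compound 1, `[O-][n+]1ccc2[nH]cnc2c1`, gives 5% in this assay. Compound 3, `c1ccc(Nc2[nH]ccc3ncnc2-3)cc1`, gives 26% in this assay, a higher reading than that of compound 1. Compound 2, `CN(C)c1nccc2c1ncn2[C@H]1C[C@H](O)[C@@H](CO)O1`, does not give a number in this assay; its reading is a limit of the assay, reported as < 5%. That limit is the limit of < 5% in this assay, at which 1 of the 3 values shown sits. Among the compounds with values here, compound 2 therefore stands at the floor of what this assay can report, and no measured pair of compounds differing in one place exists that would show how any single change in structure moves the reading.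

Compound 4, `Nc1nccc2c1ncn2[C@H]1C[C@H](O)[C@@H](CO)O1`, has not been measured. It differs from compound 2 in a single place: amino in place of dimethylamino on an aromatic carbon. Within the data shown here, with no measured step of this kind available, the size and direction of the change can only be guessed from where compound 2 stands. Compound 4 is expected to give about 8% in this assay, within a range from 0% to 25%. That estimate means a step of a number at least 3 percentage points higher from compound 2 to compound 4 (that floor lies within the scatter), which is expected to stay within the usual scatter rather than mark a real change.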

Compound 4, a percentage reported as inhibition, at one concentration (the size of the read-out at that concentration, not a potency): 89%
Estimate against measurement, compound 4: 81 percentage points below; measured number above the stated range.
By their numbers in this assay, from the lowest: compound 1; then compound 3; then compound 4.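

In this assay, within the data shown here, the change of amino in place of dimethylamino on an aromatic carbon gives a number at least 84 percentage points higher from compound 2 to compound 4 (beyond the scatter) and is the first measured change in one place. It shows that this position, next to the ring nitrogen, is far from indifferent to the group it carries: a smaller group with a hydrogen-bond donor separates a compound at the floor of the read-out from one with a high reading, a contrast that compounds 1 and 3 could not reveal, as neither differs from another compound in one place. The step gives only a lower bound on the true difference, because compound 2 has a limit and not a number: the limit of < 5% in this assay, at which 1 of the 4 values shown sits.

The compounds shown leave open whether the smaller size of amino or its hydrogen-bond donor matters more, and methylamino at the same position would sit between the two groups. They also leave open how a hydroxyl or a methoxy group would read there, and how the reading of compound 4 would change at other concentrations.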